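Thioether aryl swap in the cinnamamide series

This account rests on a few compounds, and the source may have more. Where it says the series, first, only, none or still open, it means among the compounds named here.

Measured so far:
compound 1 `Cc1ccc(SCc2ccc(/C=C/C(=O)Nc3ccccc3N)cc2)cc1` — 43.4%
compound 2 `CC(C)(C)c1ccc(SCc2ccc(/C=C/C(=O)Nc3ccccc3N)cc2)cc1` — 71.5%

Compound 2 holds the higher of the two numbers in a functional assay on A549 cells (Homo sapiens) for inhibition, read by CCK-8 assay, with a stated time of 72 h, tested at 2 uM; a higher number here means more inhibition of growth at the concentration tested, a lower number less inhibition of growth; the nearest is compound 1, and the gap between them is a number 28.1 percentage points higher from compound 1 to compound 2 (beyond the scatter). Compound 3 `Nc1ccccc1NC(=O)/C=C/c1ccc(CSc2ccc(C(F)(F)F)cn2)cc1` is not yet measured in this assay. It differs from compound 2 in one place: 5-(trifluoromethyl)pyridin-2-yl in place of 4-(tert-butyl)phenyl on a sulfur.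

Within the data shown here, only one measured step exists, from compound 1 to compound 2, and it concerns the group on the aromatic ring attached to the sulfur, not the ring itself. It shows that what sits on the sulfur can move the number by a modest amount. Among the measured compounds shown here, for compound 3 the ring on the sulfur changes together with its substituent, so no measured step bears on it directly. On these data alone, with the tert-butyl group gone, the expectation leans toward a number nearer compound 1, though the pyridinyl ring is untested and the direction is uncertain. The expected step from compound 2 is a number 16.5 percentage points lower from compound 2 to compound 3 (beyond the scatter). Compound 3 is estimated at 55%, within 30% to 80%.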

Compound 3, percent growth inhibition at one concentration: 51.7%
Estimate against measurement, compound 3: 3.3 percentage points above, and the stated range covers the measured number.
By their numbers in this assay, from the lowest: compounds 1 and 3 (each within the scatter of the next); then compound 2.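

In this assay the swap of 4-(tert-butyl)phenyl for 5-(trifluoromethyl)pyridin-2-yl on the sulfur gives a number 19.8 percentage points lower from compound 2 to compound 3 (beyond the scatter) and so shows that the number at this position also moves when the ring and its substituent change together, whereas the earlier pair changed only the substituent on a ring of carbon. The same entering group set against 4-methylphenyl gives a number 8.3 percentage points higher from compound 1 to compound 3 (within the scatter) and so leaves compound 2 alone at the top of the three, with the other two not separated in this read-out, even though the leaving and entering groups in the step from compound 2 carry the same count of heavy atoms. No measurement at hand bears on why the number moves with this change.

The compounds shown leave open whether the ring nitrogen or the exchange of tert-butyl for trifluoromethyl carries the step, and a 4-(trifluoromethyl)phenyl or a 5-(tert-butyl)pyridin-2-yl group on the sulfur would part the two. Also open, on these data alone, is how the position responds to a group of another kind on that ring, such as an amine or a carboxylic acid.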